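Removing the iodoacetyl group from an imidazoline aniline

The source may hold more compounds than are shown below. What is called first, only, known or untested is meant among the compounds shown, and "the series" means these compounds.

Measured so far:
- compound 1 `O=C(CI)Nc1ccc(CC2=NCCN2)cc1`: 25%
- compound 2 `S=C=Nc1ccc(Cc2ncc[nH]2)cc1`: 70%

In an ADME assay on the whole organism (thoracic aorta) with Rattus norvegicus as the target (on this read-out lower numbers stand for smaller maximal responses and higher numbers for larger maximal responses), compound 1 gives 25% and stands lowest of the two measured numbers; compound 2 gives 70%, a value beyond the scatter above it, though the two differ in more than one place, so no single change can be read from that gap.

Compound 3 `Nc1ccc(CC2=NCCN2)cc1` has not yet been measured. It differs from compound 1 by hydrogen in place of (iodomethyl)carbonyl on a nitrogen on an aromatic ring.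

Among the measured compounds shown here, no measured pair shows this change, so the size of the step is open. A moderate rise beyond the scatter is expected, but a flat result cannot be excluded. Compound 3 is estimated at 40%, within 15% to 70%, which means an expected step of a number 15 percentage points higher from compound 1 to compound 3 (beyond the scatter) in this assay.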

Compound 3, largest response reached (Emax), in percent of the reference or control that the assay uses: 69%
For compound 3 the middle estimate is 29 percentage points below the measured one; the range from low to high includes it.
By their numbers in this assay, from the lowest: compound 1; then compounds 3 and 2 (each within the scatter of the next).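

In this assay, swapping the (iodomethyl)carbonyl on the nitrogen for hydrogen, which turns ((iodomethyl)carbonyl)amino into amino, gives a large change: a number 44 percentage points higher from compound 1 to compound 3 (beyond the scatter). Among the compounds shown here, this is the first direct reading at this position, and it shows that what sits on this nitrogen strongly shapes the maximal response. Nothing measured here explains the size of this step. Still open, from the compounds shown here alone, is whether the iodine or the whole group accounts for it. An acetyl group, which keeps the carbonyl but has no iodine, would help separate the two.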